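A few compounds are considered here, and "the series" means these few. Any claim that something is new, unique, unknown or untested is made for them only; others in the source may bear on it.

Compound 1 `Cc1cc(-c2ccc(F)cc2)cc(C)c1Nc1ccnc(Nc2ccc(C#N)cc2)n1` was measured in an ADME assay on MT4 cells (Homo sapiens) for cytotoxicity, read by MTT assay, with a stated time of 4 days (on this read-out lower numbers stand for higher toxicity in this test and higher numbers for lower toxicity in this test), where compound 1 gives 4170 nM. Two analogues that differ from it only in the aryl group attached to the shared core were measured alongside it: compound 2 `Cc1cc(-c2cccc(Cl)c2)cc(C)c1Nc1ccnc(Nc2ccc(C#N)cc2)n1` gives 2160 nM in this assay, and compound 3 `Cc1cc(C)cc(-c2cc(C)c(Nc3ccnc(Nc4ccc(C#N)cc4)n3)c(C)c2)c1` gives 4140 nM. Of the three numbers, that of compound 1 is the highest, but neither gap to it counts for much: there is a 1.9-fold lower number from compound 1 to compound 2 (0.29 log units; within the scatter) and a 1.0-fold lower number from compound 1 to compound 3 (0.00 log units; within the scatter), and between the other two there is a 1.9-fold higher number from compound 2 to compound 3 (0.28 log units; within the scatter), so all three compounds sit within the scatter of one another in this assay.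

Compound 4 `COc1cccc(-c2cc(C)c(Nc3ccnc(Nc4ccc(C#N)cc4)n3)c(C)c2)c1` has not yet been measured. It differs from compound 1 in one place, with 3-methoxyphenyl in place of 4-fluorophenyl on an aromatic carbon. Going by the values given here, the steps that bear on this change are the two that exchange the same aryl group, from compound 1 to compound 2 and from compound 1 to compound 3, both of which stay within the scatter, as does the step from compound 2 to compound 3. On that basis no step beyond the scatter is expected in this assay in either direction, which is what a 1.1-fold lower number from compound 1 to compound 4 (0.04 log units; within the scatter) expresses. Compound 4 is therefore estimated at 3800 nM in this assay, with a range from 1800 nM to 8000 nM.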

Compound 4, half-maximal cytotoxic concentration: 2990 nM
Beside the measured number, compound 4's estimate is 1.3-fold (0.10 log units) above it, and the stated range covers the measured number.
By their numbers in this assay, from the lowest: compounds 2, 4, 3 and 1 (each within the scatter of the next).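

With 3-methoxyphenyl on this aromatic carbon, meta to two methyl groups, the aryl group carries a hydrogen-bond acceptor, which 4-fluorophenyl does not, yet this assay shows a 1.4-fold lower number from compound 1 to compound 4 (0.14 log units; within the scatter), so this exchange adds a hydrogen-bond acceptor and one heavy atom without a step beyond the scatter. The new compound also stays close to the other two analogues, with a 1.4-fold lower number from compound 3 to compound 4 (0.14 log units; within the scatter) and, where methoxy takes the place of chloro, a 1.4-fold higher number from compound 2 to compound 4 (0.14 log units; within the scatter), so all four aryl groups now shown at this position remain within the scatter of one another in this assay, and none of the compounds can be set apart from the others. Nothing at hand explains why these numbers remain so close.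

The compounds shown leave open whether an aryl group bearing a carboxylic acid or an aminomethyl group at this place would also stay within the scatter in this assay. They also leave open whether a saturated ring such as piperidine or morpholine, in place of the aryl group, would give a number close to these.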